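From 4-Chlorophenyl to Pyridin-4-yl: A Modest Loss Expected

The source may hold more compounds than are shown below. What is called first, only, known or untested is meant among the compounds shown, and "the series" means these compounds.

Compound 1 `CCOC(=O)c1ccc(-c2nn(Cc3cccc(Cl)c3)c3ccccc23)cc1`: 80 nM
Compound 2 `CCOC(=O)c1ccc(-c2nn(Cc3ccc(Cl)cc3)c3ccccc23)cc1`: 120 nM
Compound 3 `CCOC(=O)c1ccc(-c2nn(Cc3cccc(OC)c3)c3ccccc23)cc1`: 260 nM

In a functional assay on cells (Platelet, Homo sapiens) for inhibition (a lower number here means a stronger inhibitor, a higher number a weaker inhibitor), compound 2 stands second highest of the three numbers. The step of a 1.5-fold higher number from compound 1 to compound 2 (0.18 log units; within the scatter) is within the scatter, whereas a 2.2-fold higher number from compound 2 to compound 3 (0.34 log units; beyond the scatter) lies beyond it.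

Compound 4 `CCOC(=O)c1ccc(-c2nn(Cc3ccncc3)c3ccccc23)cc1` differs from compound 2 by pyridin-4-yl in place of 4-chlorophenyl on a saturated chain carbon bound to an aromatic nitrogen. Going by the values given here, no measured step swaps a carbon ring for one holding a nitrogen, so the only guidance is indirect: a 2.2-fold higher number from compound 2 to compound 3 (0.34 log units; beyond the scatter) and a 3.3-fold higher number from compound 1 to compound 3 (0.51 log units; beyond the scatter) both show a modest weakening when the chlorine-bearing ring is exchanged for a ring carrying an oxygen-bearing group. A modest weakening is therefore expected, a 2.9-fold higher number from compound 2 to compound 4 (0.46 log units; beyond the scatter), with wide uncertainty. Compound 4 is estimated at 350 nM, within a range of 120 nM to 1200 nM.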

Compound 4, half-maximal inhibitory concentration: 5630 nM
Estimate against measurement, compound 4: 16-fold (1.21 log units) below; measured number above the stated range.
By their numbers in this assay, from the lowest: compounds 1 and 2 (each within the scatter of the next); then compound 3; then compound 4.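

Putting a ring nitrogen on this saturated chain carbon's ring costs far more than any earlier change: pyridin-4-yl gives large losses against all three rings carrying chloro or methoxy (a 47-fold higher number from compound 2 to compound 4 (1.67 log units; beyond the scatter); a 22-fold higher number from compound 3 to compound 4 (1.34 log units; beyond the scatter); a 70-fold higher number from compound 1 to compound 4 (1.85 log units; beyond the scatter)). The earlier compounds shown here showed only small shifts when these substituents were changed, so this position is much less forgiving of a change to the ring itself than they suggested. No measurement shown here explains the size of this drop.

From the compounds shown here alone, it remains open whether the loss follows the ring nitrogen itself or its place in the ring, and what pyridin-3-yl, pyridin-2-yl or unsubstituted phenyl would give here.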